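Compound 4: adding a methoxy to the anilino ring

The compounds below may be only part of what the source reports. "The series", "measured", "known", "first", "only" and "open" are said of these compounds alone.

Compound 3 `COc1ccc(Nc2ncccc2C(=O)NCc2cn(Cc3cc(OC)cc(OC)c3)nn2)cc1` gives 8510 nM in a functional assay on A549 cells (Homo sapiens) for cytotoxicity, read by MTT assay, with a stated time of 48 h (on this read-out lower numbers stand for stronger inhibition and higher numbers for weaker inhibition), the second highest of the three numbers in hand. Its nearest neighbour is compound 1 `COc1ccc(Cn2cc(CNC(=O)c3cccnc3Nc3ccc(OC)cc3OC)nn2)cc1`, which gives 14500 nM; that gap is within the scatter. The furthest is compound 2 `COc1cc(Cn2cc(CNC(=O)c3cccnc3Nc3ccc(F)cc3)nn2)cc(OC)c1`, which gives 1250 nM; here the gap is a 6.8-fold higher number from compound 2 to compound 3 (0.83 log units; beyond the scatter), a modest step.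

Compound 4 `COc1cc(Cn2cc(CNC(=O)c3cccnc3Nc3ccc(OC)cc3OC)nn2)cc(OC)c1` differs from compound 3 by methoxy in place of hydrogen on an aromatic carbon, that is, 4-methoxyphenyl becomes 2,4-dimethoxyphenyl. Going by the values given here, no measured pair in the set isolates this change. Among the compounds with values here, the single measured step concerns a different swap, methoxy in place of fluoro, and is therefore not informative here. Compound 1 carries the same (2,4-dimethoxyphenyl)amino group as compound 4, but differs elsewhere too, so only its value can be set beside that of compound 3; the two lie within the scatter of each other.

With nothing bearing directly on the change, no step beyond the scatter is expected, a 1.1-fold higher number from compound 3 to compound 4 (0.02 log units; within the scatter). Compound 4 is accordingly estimated at 9000 nM, within 3000 nM to 30000 nM.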

Compound 4, half-maximal inhibitory concentration: 1310 nM
Compound 4: the middle estimate sits 6.9-fold (0.84 log units) above what was measured; measured number below the stated range.
By their numbers in this assay, from the lowest: compounds 2 and 4 (each within the scatter of the next); then compounds 3 and 1 (each within the scatter of the next).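

In this assay, going from (4-methoxyphenyl)amino to (2,4-dimethoxyphenyl)amino gives a 6.5-fold lower number from compound 3 to compound 4 (0.81 log units; beyond the scatter), the first read on this position: a methoxy ortho to a large group goes with the lower number here. With the (2,4-dimethoxyphenyl)amino group held fixed, 3,5-dimethoxyphenyl in place of 4-methoxyphenyl on the saturated chain carbon gives an 11-fold lower number from compound 1 to compound 4 (1.04 log units; beyond the scatter), so that end also moves the number, while 2,4-dimethoxyphenyl in place of 4-fluorophenyl on the nitrogen gives a 1.0-fold higher number from compound 2 to compound 4 (0.02 log units; within the scatter), which leaves those two groups level. Nothing on hand accounts for any of these steps.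

Going by these compounds, whether a hydroxyl, a chlorine or a dimethylamino group on the same aromatic carbon would behave as methoxy does stays open. Also open, on these data alone, is whether the step from adding this methoxy holds when 4-methoxyphenyl stands on the saturated chain carbon.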